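Notes on the propargyl to allyl thioether step

A few compounds are considered here, and "the series" means these few. Any claim that something is new, unique, unknown or untested is made for them only; others in the source may bear on it.

Compound 1 `Cc1ccc(C(=O)CSc2nnc(C)n2N2C(=O)c3ccccc3C2=O)cc1` is recorded in a functional assay on MKN-45 cells (Homo sapiens) for cytotoxicity, read by MTT assay, with a stated time of 48 h (on this read-out lower numbers stand for stronger inhibition and higher numbers for weaker inhibition), only as a limit, giving > 200000 nM. Compound 2 `C#CCSc1nnc(C)n1N1C(=O)c2ccccc2C1=O` likewise gives only the limit > 200000 nM. Compound 3 `C#CCSc1nnc(CC)n1N1C(=O)c2ccccc2C1=O` stands at the same limit, giving > 200000 nM. The step that the two limits leave unreadable from compound 1 to compound 2 and the step that the two limits leave unreadable from compound 2 to compound 3 cannot be sized, as the limit of > 200000 nM in this assay, at which 3 of the 3 values shown sit, shows. Compound 4 `C=CCSc1nnc(CC)n1N1C(=O)c2ccccc2C1=O` differs from compound 3 by vinyl in place of ethynyl on a saturated chain carbon bound to a sulfur. Going by the values given here, no measured step touches this change, and none of the steps at hand carries a readable size, so nothing argues for a move away from the limit. The step that the limit leaves unreadable from compound 3 to compound 4 is expected to stay unreadable in the same way. Compound 4 is expected to give about 250000 nM, within 100000 nM to 600000 nM, most likely reported again as a limit.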

Compound 4, half-maximal inhibitory concentration: > 200000 nM
Compound 4: a limit, no number (the forecaster's own chance of this, stated with the estimate: 85%); the middle value does not contradict the limit.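

No step can be read from compound 3 to compound 4, since both are recorded only as limits: the limit of > 200000 nM in this assay, at which 4 of the 4 values shown sit.

The compounds shown leave open whether vinyl and ethynyl on a saturated chain carbon bound to a sulfur differ at all in this assay.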